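Vinyl for Nitro: Expected Cytotoxicity of Compound 3

The compounds below may be only part of what the source reports. "The series", "measured", "known", "first", "only" and "open" are said of these compounds alone.

Measured compounds:
compound 1, `C/C(=C\c1cc(-c2ccc(F)cc2)cs1)C(N)=O`: > 50000 nM
compound 2, `C/C(=C\c1cc(-c2ccc([N+](=O)[O-])cc2)cs1)C(N)=O`: 2380 nM

In a functional assay on HO8910 cells (Homo sapiens) for cytotoxicity, read by CCK-8 assay, with a stated time of 24 h (a lower number here means a stronger inhibitor, a higher number a weaker inhibitor), compound 1 reaches only a limit, > 50000 nM. In this assay, within the data shown here, compound 2 gives 2380 nM, the only true number among the two values, so compound 2 stands alone as the measured reference. Among the measured compounds shown here, the one measured step is an at least 21-fold lower number from compound 1 to compound 2 (1.32 log units; beyond the scatter), and it rests on the limit of > 50000 nM in this assay, at which 1 of the 2 values shown sits, for compound 1.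

Compound 3, `C=Cc1ccc(-c2csc(/C=C(\C)C(N)=O)c2)cc1`, differs from compound 2 by vinyl in place of nitro on an aromatic carbon. For the measured compounds named here, the single step bears on it only indirectly: removing the nitro group reverses the large change seen from compound 1 to compound 2, and vinyl is neither of the two measured groups. Compound 3 is therefore expected to move toward the weaker side, by a 6.3-fold higher number from compound 2 to compound 3 (0.80 log units; beyond the scatter) in this assay. For compound 3 the estimate is 15000 nM, within 3000 nM to 50000 nM.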

Compound 3, half-maximal inhibitory concentration: > 50000 nM
Compound 3: only a limit was reported; the forecaster's own chance of this, stated with the estimate: 30%; at least 3.3-fold (0.52 log units) between middle value and limit.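

Vinyl in place of nitro, on an aromatic carbon para to a large group, gives an at least 21-fold higher number from compound 2 to compound 3 (1.32 log units; beyond the scatter) in this assay. Nitro and vinyl each carry one double bond outside aromatic rings, so that count alone does not keep a measurable value at this place, while nitro brings hydrogen-bond acceptors and vinyl brings none. Of fluoro, nitro and vinyl, only nitro now gives a true number, and the other two values are a limit: the limit of > 50000 nM in this assay, at which 2 of the 3 values shown sit.

The step from compound 1 to compound 3 cannot be read, since both values are limits, so fluoro and vinyl cannot be ranked. From the compounds shown here alone, whether a true number here depends on acceptor atoms stays open, and a nitrile, a methoxy group or an amine in the same place would bear on that.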